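A few compounds are considered here, and "the series" means these few. Any claim that something is new, unique, unknown or untested is made for them only; others in the source may bear on it.

Going by the values given here, compound 3 `COc1ccc(Nc2c(C(C)=O)c(C)nn(CC(=O)Nc3ccc(Br)cc3)c2=O)cc1` is one of three compounds measured in an assay on HL-60 cells for agonist activity at N-formyl peptide receptor 3 (Homo sapiens), read by calcium flux; on this read-out lower numbers stand for an effect already at smaller amounts and higher numbers for an effect only at larger amounts of compound. In this assay compound 3 reaches only a limit of the assay, > 50000 nM. Compound 1 `Cc1cc(Cc2cccc(F)c2)c(=O)n(CC(=O)Nc2ccc(Br)cc2)n1` likewise gives only a limit, > 50000 nM. Among the compounds with values here, compound 2 `Cc1cc(Cc2cccs2)c(=O)n(CC(=O)Nc2ccc(Br)cc2)n1` gives a number, 10200 nM, and the single counted step, an at least 4.9-fold lower number from compound 1 to compound 2 (0.69 log units; beyond the scatter), concerns the group on the saturated chain carbon and lies beyond the scatter; it stands apart from the limit of > 50000 nM in this assay, at which 2 of the 3 values shown sit. Compound 4 `COc1ccc(Nc2cc(C)nn(CC(=O)Nc3ccc(Br)cc3)c2=O)cc1` differs from compound 3 by hydrogen in place of acetyl on an aromatic carbon. No measured step touches this position, so the shown numbers give no direction for it, and compound 3 starts at a limit. The estimate for compound 4 is 40000 nM, with a range from 8000 nM to 200000 nM. That corresponds to an expected step of an at least 1.2-fold lower number from compound 3 to compound 4 (0.09 log units; that floor lies within the scatter).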

Compound 4, half-maximal effective concentration: > 50000 nM
Compound 4 was reported as a limit (the forecaster's own chance of this, stated with the estimate: 60%); middle value at least 1.2-fold (0.09 log units) from the limit.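

With hydrogen in place of acetyl on this aromatic carbon, compound 4 still gives only a limit in this assay, not a number: the limit of > 50000 nM in this assay, at which 3 of the 4 values shown sit. The steps from compound 3 and from compound 1 to compound 4 join two limits and cannot be read. Going by these compounds alone, the one readable step is an at least 4.9-fold higher number from compound 2 to compound 4 (0.69 log units; beyond the scatter), with (4-methoxyphenyl)amino in place of (thiophen-2-yl)methyl.

On these data alone, whether acetyl or hydrogen at this position makes any difference stays open, with both compounds at a limit. Also open, as far as these compounds go, is whether a carboxylic acid here, or a simple amine in place of (4-methoxyphenyl)amino, would give a number.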